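The source may report more compounds than this note shows. Statements on the series, on what has been measured and on what is new or still open speak of the compounds shown alone.

Measured so far in an assay on HT-29 cells for inhibition of Serine-protein kinase ATM (Homo sapiens), read by fluorescence, with a stated time of 1 h; on this read-out higher numbers stand for weaker inhibition and lower numbers for stronger inhibition:

- compound 1 `C[C@@H](Nc1c(C(N)=O)cnc2ccc(-c3cccnc3)cc12)c1ccc(Cl)cc1`: 109 nM
- compound 2 `NC(=O)c1cnc2ccc(-c3cccnc3)cc2c1SC1CCCC1`: 9700 nM

Compound 2 gives the higher of the two numbers; compound 1 sits at a much lower value, a gap well beyond the scatter of this assay. Among the compounds with values here, no single-point step between the two measured compounds is available, so their two values are read only as they stand.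

The next compound in the series, compound 3 `NC(=O)c1cnc2ccc(-c3cccnc3)cc2c1NC1CCCCC1`, has not yet been measured. It differs from compound 2 in one place: cyclohexylamino in place of cyclopentylsulfanyl on an aromatic carbon. The entering group carries one hydrogen-bond donor where the leaving group carried none.

For compound 3 a clearly lower number than for compound 2 is expected in this assay, a step beyond the scatter, since compound 1, the only other point, gives 109 nM and the series has so far shown large movement between its members. The estimate for compound 3 is 900 nM, with a range from 150 nM to 4500 nM. That estimate corresponds to an expected step of an 11-fold lower number from compound 2 to compound 3 (1.03 log units; beyond the scatter).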

Compound 3, half-maximal inhibitory concentration: 132 nM
Compound 3: the middle estimate sits 6.8-fold (0.83 log units) above what was measured, outside the stated range (below it).
By their numbers in this assay, from the lowest: compounds 1 and 3 (each within the scatter of the next); then compound 2.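

Working from this assay, the position opposite the ring nitrogen proves highly sensitive to the group it carries: cyclohexylamino in place of cyclopentylsulfanyl gives a large step (a 73-fold lower number from compound 2 to compound 3 (1.87 log units; beyond the scatter)). That swap changes the atom attached to the aromatic carbon and the ring size together, and it adds a hydrogen-bond donor, so the step cannot be assigned to any one of these differences. With the nitrogen kept, cyclohexyl in place of 1-(4-chlorophenyl)ethyl leaves the number within the scatter (a 1.2-fold higher number from compound 1 to compound 3 (0.08 log units; within the scatter)), so for this pair an aromatic ring on that nitrogen is not needed to keep the value, and no evidence on hand explains either step.

The compounds shown leave the contributions of the attached atom and ring size unseparated, a question that cyclopentylamino and cyclohexylsulfanyl would address directly. Also open, from the compounds shown here alone, is whether the hydrogen on the nitrogen matters, which an N-methyl-N-cyclohexylamino group would test, and how far the nitrogen substituent can shrink, as with a simple methylamino group.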